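The source may hold more compounds than are shown below. What is called first, only, known or untested is meant among the compounds shown, and "the series" means these compounds.

Measured compounds:
compound 1 `CC(C)NC(=N)c1ccc2cc(-c3cccc(OCCCCCCOc4ccccc4)c3)oc2c1` gives 10100 nM
compound 2 `c1ccc(OCCCCCCOc2cccc(-c3cc4ccc(C5=NCCN5)cc4o3)c2)cc1` gives 1800 nM
compound 3 `CC(C)NC(=N)c1ccc2oc(-c3ccc(OCCCCOc4ccccc4)cc3)cc2c1` gives 6900 nM

All three were tested in an ADME assay on L6 cells (Rattus norvegicus) for cytotoxicity, read by resazurin assay, with a stated time of 70 h; on this read-out lower numbers stand for stronger inhibition and higher numbers for weaker inhibition. Compound 1 and compound 2 share one core and differ only in a single group on an aromatic carbon: a group of 5 heavy atoms (3 carbon, 2 nitrogen; one five-membered non-aromatic ring with 2 hetero atoms) in place of a group of 6 heavy atoms (4 carbon, 2 nitrogen; no ring), on an aromatic carbon. That exchange brought a 5.6-fold lower number from compound 1 to compound 2 (0.75 log units; beyond the scatter). Compound 3 has a different core, and the difference between the two cores is not broken down here; in this assay compound 3 gives 6900 nM, with compound 1 giving 10100 nM, the two within the usual scatter of each other.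

Compound 4 `c1ccc(OCCCCOc2ccc(-c3cc4cc(C5=NCCN5)ccc4o3)cc2)cc1` has not yet been measured in this assay . It is made from compound 3 by the same change that turned compound 1 into compound 2: a group of 5 heavy atoms (3 carbon, 2 nitrogen; one five-membered non-aromatic ring with 2 hetero atoms) in place of a group of 6 heavy atoms (4 carbon, 2 nitrogen; no ring), on an aromatic carbon. The group enters at a place described in the same words as before, so the change is the same one, now on the core of compound 3. Going by the values given here, since that one earlier case is the only guide, and the step it gave was a 5.6-fold lower number from compound 1 to compound 2 (0.75 log units; beyond the scatter), the expected step on the new core is estimated as a 4.6-fold lower number from compound 3 to compound 4 (0.66 log units; beyond the scatter), which rests on compound 3 starting from 6900 nM. Compound 4 is therefore expected to give roughly 1500 nM in this assay , with a likely range from 600 nM to 4000 nM.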

Compound 4, half-maximal inhibitory concentration: 2900 nM
For compound 4 the middle estimate is 1.9-fold (0.29 log units) below the measured one; low and high end bracket the measured number.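

In this assay, replacing the ringless group of 6 heavy atoms with the five-membered non-aromatic ring with 2 hetero atoms again gave a lower number on the second core, with a 2.4-fold lower number from compound 3 to compound 4 (0.38 log units; beyond the scatter). The direction of the step therefore carried over from one core to the other, and its size did not differ beyond what repeated measurements would allow: the same change on two cores in this assay, a 5.6-fold lower number (0.75 log units; beyond the scatter) from compound 1 to compound 2 and a 2.4-fold lower number (0.38 log units; beyond the scatter) from compound 3 to compound 4, 2.4-fold (0.37 log units) apart, within the scatter of two such steps. Going by these compounds alone, this is still only two pairs of compounds, so it supports carrying the change across these two cores but does not establish a rule for the series or show that the step would appear on a third core or in any other test.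

The compounds shown leave open how other groups would behave at the same aromatic carbon, such as a simple amine, a carboxylic acid or a six-membered ring in place of the five-membered one. They also leave open whether the step would keep its direction and size with a longer chain on the core of compound 3, or with a shorter chain on the core of compound 1.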